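Replacing an aryl group with cyclopropylmethyl on the ring nitrogen

The source may report more compounds than this note shows. Statements on the series, on what has been measured and on what is new or still open speak of the compounds shown alone.

Of the compounds shown here, three sharing one core have been tested in an assay on Huh-7 cells for agonist activity at Bile acid receptor (Homo sapiens), read by a luciferase reporter; a higher number here means that more compound is needed for the effect, a lower number that less compound is needed. Compound 1 `CCC(CC)n1c(-c2ccc(OCc3c(-c4c(Cl)cccc4Cl)noc3C(C)C)cc2)nc2ccc(C(=O)O)cc21` carries a pentan-3-yl group on the ring nitrogen and gives 0.8 nM. Compound 2 `CCCn1c(-c2ccc(OCc3c(-c4c(Cl)cccc4Cl)noc3C(C)C)cc2)nc2ccc(C(=O)O)cc21` carries a propyl group in the same place and gives 9.3 nM. Compound 3 `CC(C)c1onc(-c2c(Cl)cccc2Cl)c1COc1ccc(-c2nc3ccc(C(=O)O)cc3n2-c2ccc(F)cc2)cc1` carries a 4-fluorophenyl group there and gives 32.2 nM, the highest of the three numbers; the step of a 3.5-fold higher number from compound 2 to compound 3 (0.54 log units; beyond the scatter) is modest, while the step of a 40-fold higher number from compound 1 to compound 3 (1.60 log units; beyond the scatter) is large, so the aryl group on the ring nitrogen is clearly the weakest of the three options here.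

Compound 4 `CC(C)c1onc(-c2c(Cl)cccc2Cl)c1COc1ccc(-c2nc3ccc(C(=O)O)cc3n2CC2CC2)cc1` has not yet been measured. It differs from compound 3 by cyclopropylmethyl in place of 4-fluorophenyl on an aromatic nitrogen. The two steps that bear on this change run the other way: both replace a saturated chain on the nitrogen with the aryl group and both raise the number. Cyclopropylmethyl is a saturated group of four heavy atoms, so the change from compound 3 to compound 4 is expected to lower the number in this assay, most likely by a step between those seen for propyl and pentan-3-yl, estimated as an 8.1-fold lower number from compound 3 to compound 4 (0.91 log units; beyond the scatter). Compound 4 is therefore expected to give about 4 nM, within a range from 1 nM to 15 nM.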

Compound 4, half-maximal effective concentration: 19.4 nM
Compound 4: middle estimate off by 4.9-fold (0.69 log units), on the low side; the measured number lies above the stated range.
By their numbers in this assay, from the lowest: compound 1; then compound 2; then compounds 4 and 3 (each within the scatter of the next).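

In this assay, removing the aromatic ring does not by itself lower the number: a 1.7-fold lower number from compound 3 to compound 4 (0.22 log units; within the scatter) leaves these two compounds indistinguishable, even though 4-fluorophenyl and cyclopropylmethyl differ in ring type and heavy-atom count. Nor do all saturated groups on this nitrogen behave alike, since a 2.1-fold higher number from compound 2 to compound 4 (0.32 log units; beyond the scatter) and a 24-fold higher number from compound 1 to compound 4 (1.38 log units; beyond the scatter) place cyclopropylmethyl on the high side of both propyl and pentan-3-yl, with the gap to pentan-3-yl far the larger. So the low number of compound 1 cannot be credited simply to having a saturated group here, and nothing in the data gives a reason for the differences among these groups.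

Within the data shown here, with only three saturated groups at this position, it remains open which feature of pentan-3-yl goes with the low number of compound 1. A cyclopentyl group, which joins the two ethyl arms of pentan-3-yl into a ring, and a butyl chain on the same nitrogen would help show whether the ring in cyclopropylmethyl or the shape of the group matters more.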